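This account rests on a few compounds, and the source may have more. Where it says the series, first, only, none or still open, it means among the compounds named here.

Among the measured compounds shown here, in a physicochemical assay, read by spectrophotometry, with a stated time of 6 min (on this read-out higher numbers stand for weaker inhibition and lower numbers for stronger inhibition), compound 1 `COc1cc(/C=N/NC(=O)CCc2nc3ccccc3c(=O)[nH]2)cc(OC)c1OC` gives 55000000 nM, the lower of the two numbers so far and thus the stronger inhibition. Compound 2 `COc1ccc(/C=N/NC(=O)CCCc2nc3ccccc3c(=O)[nH]2)cc1` gives 180000000 nM, a gap that lies beyond the usual scatter. The next compound, compound 3 `COc1cc(/C=N/NC(=O)CCc2nc3ccccc3c(=O)[nH]2)cc(OC)c1O`, keeps the rest of compound 1 and changes one group, with hydrogen in place of methyl on an oxygen on an aromatic ring, so that a methoxy becomes a hydroxy. For the measured compounds named here, no measured pair shows this change, so the expectation rests on judgement alone. A clear move towards stronger inhibition, beyond the scatter, is expected, and the estimated step is an 11-fold lower number from compound 1 to compound 3 (1.04 log units; beyond the scatter). For compound 3 the expected value is 5000000 nM, with an estimated range from 400000 nM to 35000000 nM.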

Compound 3, half-maximal inhibitory concentration: 105000000 nM
The estimate for compound 3 lay 21-fold (1.32 log units) below the measured number, outside the stated range (above it).
By their numbers in this assay, from the lowest: compounds 1, 3 and 2 (each within the scatter of the next, the first and the last beyond it).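

In this assay, hydrogen in place of methyl on an oxygen on an aromatic ring gives a 1.9-fold higher number from compound 1 to compound 3 (0.28 log units; within the scatter), so this methoxy-to-hydroxy change leaves compound 1 and compound 3 indistinguishable on this read-out. Among the compounds shown here, this is the first matched pair, and it shows that the methyl on this oxygen can be lost, along with its single carbon, without a difference that exceeds the scatter. Nothing measured here offers an explanation for this outcome.

From the compounds shown here alone, it remains open whether a larger ether such as ethoxy, or an amine or a carboxylic acid on the aromatic ring in place of this methoxy, would shift the number beyond the scatter. The same question stands for replacing either remaining methoxy of compound 3 with hydroxy.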